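This account rests on a few compounds, and the source may have more. Where it says the series, first, only, none or still open, it means among the compounds named here.

Compound 1, `NC/C(=C\c1ccccc1)C(=O)O`: -2.4%
Compound 2, `N#C/C(=C\c1ccoc1)C(=O)O`: 30.7%
Compound 3, `NC/C(=C\c1ccoc1)C(=O)O`: -1.5%

All three measured compounds were tested in a functional assay on the whole organism (strain CD1) for inhibition, with Mus musculus as the target, with stated times of 15 min and 20 min, at a dose of 10 mg/kg by the subcutaneous route; on this read-out higher numbers stand for more inhibition at the one dose given (going by the name of the read-out) and lower numbers for less inhibition. Compound 2 stands highest of the three numbers in this assay. Its nearest neighbour is compound 3, and the step between them is large: a number 32.2 percentage points lower from compound 2 to compound 3 (beyond the scatter). Compound 1 lies furthest from it, giving -2.4% in this assay, and nothing more than the two values themselves can be said of that pair.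

The unmeasured compound 4, `CCOC(=O)/C(C#N)=C/c1ccoc1`, is derived from compound 2 by a single change: ethyl in place of hydrogen on an oxygen next to a carbonyl group. This is ethyl in place of hydrogen on an oxygen next to a carbonyl group. Among the measured compounds shown here, no measured step bears on this change. For the measured compounds named here, the only step recorded, the one from compound 2 to compound 3, alters the cyano group on the double-bonded chain carbon, not the oxygen next to the carbonyl, so it gives no guidance on the present replacement. The direction and size of the effect in this assay are therefore open, and the estimate must be wide.

Compound 4 is expected to give 22% in this assay, within a range of -5% to 45%. This estimate corresponds to an expected step of a number 8.7 percentage points lower from compound 2 to compound 4 (within the scatter), which may well lie within the scatter.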

Compound 4, a percentage reported as inhibition, in the whole organism at one dose (the size of the read-out at that dose, not a potency): 55.9%
The estimate for compound 4 lay 33.9 percentage points below the measured number, outside the stated range (above it).
By their numbers in this assay, from the lowest: compounds 1 and 3 (each within the scatter of the next); then compound 2; then compound 4.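

In this assay, ethyl in place of hydrogen on an oxygen next to a carbonyl group gives a number 25.2 percentage points higher from compound 2 to compound 4 (beyond the scatter). Among the compounds shown here, this is the first change at this oxygen: compounds 1, 2 and 3 all carry the hydroxy, so they could not show whether its hydrogen was needed, and this pair shows that the read-out at this dose does not depend on it, at least with the nitrile and the core of compound 2 in place. Nothing available accounts for the direction or size of this step, whether in the ethyl itself or in what becomes of the compound in the animal.

The compounds shown leave open whether a methyl, a longer chain such as butyl, or an amine taking the place of the ethoxy would carry the number further, hold it or lose it, so one ethyl cannot be read as a trend. They also leave open whether the same change from hydroxy to ethoxy would raise the number on the core of compound 3, which carries aminomethyl instead of the nitrile and stands near zero in this read-out.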